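A few compounds are considered here, and "the series" means these few. Any claim that something is new, unique, unknown or untested is made for them only; others in the source may bear on it.

Of the compounds shown here, three that share one core have been measured in a functional assay on MCF7 cells (Homo sapiens) for antiproliferative activity, with a stated time of 5 days; on this read-out lower numbers stand for stronger inhibition and higher numbers for weaker inhibition. Compound 1 (`CCCCc1ccc2[nH]c(-c3ccc(OC)cc3)c(C=O)c2c1`) gives 22 nM, and compound 2 (`CCCCc1ccc2[nH]c(-c3ccc(CC)cc3)c(C=O)c2c1`) gives 58 nM. That second result is a 2.6-fold higher number from compound 1 to compound 2 (0.42 log units; beyond the scatter), but it comes from a change elsewhere on the molecule and says little about the step followed here. Compound 3 (`CCCCc1ccc2[nH]c(-c3ccc(OC)cc3)c(/C=N/O)c2c1`) gives 212 nM, the highest number of the three.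

Compound 4 (`CCCCc1ccc2[nH]c(-c3ccc(OC)cc3)c(/C=N/NC(=O)c3ccccc3)c2c1`) has not yet been measured. Its difference from compound 3 is benzamido in place of hydroxy on a double-bonded nitrogen, which means benzamido in place of hydroxy on a double-bonded nitrogen. The most relevant measured change is at the same side group, where enlarging it gave a 9.6-fold higher number from compound 1 to compound 3 (0.98 log units; beyond the scatter). Among the measured compounds shown here, that single step suggests that a much larger group may again raise the number moderately, although no measured compound carries benzamido, so the range must stay wide. The expected change is a 2.1-fold higher number from compound 3 to compound 4 (0.33 log units; beyond the scatter). For compound 4 the estimated value in this assay is 450 nM, with an expected range from 110 nM to 1900 nM.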

Compound 4, half-maximal inhibitory concentration: 130 nM
Compound 4: middle estimate off by 3.5-fold (0.54 log units), on the high side; low and high end bracket the measured number.
By their numbers in this assay, from the lowest: compound 1; then compound 2; then compounds 4 and 3 (each within the scatter of the next).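

Benzamido in place of hydroxy on the double-bonded nitrogen gives a 1.6-fold lower number from compound 3 to compound 4 (0.21 log units; within the scatter) in this assay, so compound 3 and compound 4 cannot be told apart on this read-out. Among the compounds shown here, the earlier step at this side group, a 9.6-fold higher number from compound 1 to compound 3 (0.98 log units; beyond the scatter), showed only that the number can shift here; this new step adds that benzamido, with its six-membered aromatic ring, can replace hydroxy on this nitrogen without a change beyond the scatter. No measurement available here explains this result.

On these data alone, whether the aromatic ring of benzamido matters remains open, since a smaller acetamido group or a plain amine on this nitrogen would be needed to test it. It is also unknown how a carboxylic acid on that ring would read in this assay.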